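Cyclopropyl in place of trifluoromethylphenyl on the amide chain

The source may report more compounds than this note shows. Statements on the series, on what has been measured and on what is new or still open speak of the compounds shown alone.

In an ADME assay on C8166 cells (Homo sapiens) for cytotoxicity, read by MTT assay, with a stated time of 3 days (a higher number here means that more compound is tolerated, a lower number that less compound is tolerated), compound 3 `CC(C)(NC(=O)OCc1ccccc1)c1nc(O)c(O)c(C(=O)NCc2ccc(C(F)(F)F)cc2)n1` gives 58100 nM, the lower of the two numbers recorded. Compound 1 `COCCNC(=O)c1nc(C(C)(C)NC(=O)OCc2ccccc2)nc(O)c1O` gives 348000 nM, and the step of a 6.0-fold lower number from compound 1 to compound 3 (0.78 log units; beyond the scatter) lies beyond the scatter. Compound 2 `CC(C)(NC(=O)OCc1ccccc1)c1nc(O)c(O)c(C(=O)NN)n1` reaches only the limit > 500000 nM, and the limit of > 500000 nM in this assay, at which 1 of the 3 values shown sits, marks where that limit sits. Compound 4 `CC(C)(NC(=O)OCc1ccccc1)c1nc(O)c(O)c(C(=O)NCC2CC2)n1` carries the change (cyclopropyl in place of 4-(trifluoromethyl)phenyl on a saturated chain carbon bound to an amide-type nitrogen). Among the compounds with values here, two measured steps bear on it, a 6.0-fold lower number from compound 1 to compound 3 (0.78 log units; beyond the scatter) and an at least 8.6-fold lower number from compound 2 to compound 3 (0.93 log units; beyond the scatter), both arriving at the lowest number once the 4-(trifluoromethyl)benzyl group is present. Replacing it with the smaller cyclopropylmethyl group is expected to move the number back up, by about a 3.4-fold higher number from compound 3 to compound 4 (0.54 log units; beyond the scatter) in this assay. Compound 4 is therefore estimated at 200000 nM, with a range from 70000 nM to 500000 nM.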

Compound 4, half-maximal cytotoxic concentration: 204000 nM
Compound 4: the middle estimate sits 1.0-fold (0.01 log units) below what was measured; low and high end bracket the measured number.
By their numbers in this assay, from the lowest: compound 3; then compounds 4 and 1 (each within the scatter of the next). At a limit, above all of these: compound 2.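

In this assay, cyclopropyl in place of 4-(trifluoromethyl)phenyl gives a 3.5-fold higher number from compound 3 to compound 4 (0.55 log units; beyond the scatter), so an amide chain ending in a ring does not by itself bring the low number of compound 3. The cyclopropylmethyl and 2-methoxyethyl chains cannot be told apart here, with a 1.7-fold lower number from compound 1 to compound 4 (0.23 log units; within the scatter). The remaining step, an at least 2.4-fold lower number from compound 2 to compound 4 (0.38 log units; beyond the scatter), starts from a limit and is only a floor: the limit of > 500000 nM in this assay, at which 1 of the 4 values shown sits.

Still open, going by these compounds, is whether the low number of compound 3 follows the phenyl ring or its trifluoromethyl group. A plain benzyl group on the amide nitrogen would separate the two.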